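This account rests on a few compounds, and the source may have more. Where it says the series, first, only, none or still open, it means among the compounds named here.

Of the compounds shown here, three have been tested for how strongly they harm the growth of a non-cancerous human breast cell line. Compound 1 `Cc1ccc(-c2ccc(F)cc2)n1-c1ccc(-c2nc3ccccc3s2)cc1`, compound 2 `COc1ccc(-c2ccc(C)n2-c2ccc(-c3nc4ccccc4s3)cc2)cc1` and compound 3 `COc1ccc2nc(-c3ccc(-n4c(C)ccc4-c4ccc(F)cc4)cc3)sc2c1` are close relatives. In an ADME assay on MCF-10A cells (Homo sapiens) for cytotoxicity, read by MTT assay, with a stated time of 72 h (on this read-out higher numbers stand for weaker inhibition and lower numbers for stronger inhibition), compound 1 gives 40000 nM, compound 2 gives 36300 nM and compound 3 gives 38300 nM. Compound 2 arises from compound 1 through (methoxy in place of fluoro on an aromatic carbon), and that change brought a 1.1-fold lower number from compound 1 to compound 2 (0.04 log units; within the scatter). The core of compound 3 differs from the core of compound 1 through (methoxy in place of hydrogen on an aromatic carbon), which came with a 1.0-fold lower number from compound 1 to compound 3 (0.02 log units; within the scatter). Compound 4 `COc1ccc(-c2ccc(C)n2-c2ccc(-c3nc4ccc(OC)cc4s3)cc2)cc1` has not yet been measured. Within the data shown here, it arises from compound 3 through (methoxy in place of fluoro on an aromatic carbon), which is the same change as the one from compound 1 to compound 2, made at the same kind of place. Because that change earlier gave a 1.1-fold lower number from compound 1 to compound 2 (0.04 log units; within the scatter), a step of similar size is expected from compound 3 to compound 4, namely a 1.1-fold lower number from compound 3 to compound 4 (0.04 log units; within the scatter). Compound 4 is therefore estimated at 35000 nM in this assay, with a likely range from 18000 nM to 70000 nM.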

Compound 4, half-maximal inhibitory concentration: 30600 nM
Compound 4: the middle estimate sits 1.1-fold (0.06 log units) above what was measured; the measured number falls inside the stated range.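

In this assay, putting methoxy in place of fluoro gave a 1.3-fold lower number from compound 3 to compound 4 (0.10 log units; within the scatter), and this step matches its earlier counterpart: the same change on two cores in this assay, a 1.1-fold lower number (0.04 log units; within the scatter) from compound 1 to compound 2 and a 1.3-fold lower number (0.10 log units; within the scatter) from compound 3 to compound 4, 1.1-fold (0.06 log units) apart, within the scatter of two such steps. Putting methoxy in place of hydrogen on an aromatic carbon gave a 1.2-fold lower number from compound 2 to compound 4 (0.07 log units; within the scatter), and this step also matches its earlier counterpart: the same change on two cores in this assay, a 1.0-fold lower number (0.02 log units; within the scatter) from compound 1 to compound 3 and a 1.2-fold lower number (0.07 log units; within the scatter) from compound 2 to compound 4, 1.1-fold (0.06 log units) apart, within the scatter of two such steps. Among these compounds, both changes therefore look the same on the two cores tested, but since every step lies within the scatter, this shows only that neither change measurably shifted the number on either core, not that a change with a clear effect would carry over in the same way.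

The compounds shown leave open whether a quite different group, such as an amine or a carboxylic acid, in place of the fluoro of the 4-fluorophenyl would shift the number beyond the scatter. They also leave open whether such a shift would then be the same size on both cores.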